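A Methyl Branch on the Amide-Bearing Chain

The source may hold more compounds than are shown below. What is called first, only, known or untested is meant among the compounds shown, and "the series" means these compounds.

Measured so far:
compound 1 `COc1ccc(C(=C/C=C/C(=O)NCCCCc2cccnc2)c2ccc(OC)c(OC)c2)cc1OC`, 55 nM
compound 2 `O=C(/C=C/C=C(c1ccc(F)cc1)c1ccc(F)cc1)NCCCCc1cccnc1`, 40 nM
compound 3 `COc1ccc(C(=C/C=C/C(=O)N[C@@H](CCCc2cccnc2)C2CC2)c2ccc(OC)cc2)cc1`, 60 nM

In an assay (Canis lupus familiaris) for binding affinity to platelet-activating factor receptor (Homo sapiens), read by radioligand binding (on this read-out higher numbers stand for weaker inhibition and lower numbers for stronger inhibition), compound 1 gives 55 nM, the second highest of the three numbers; compound 3 gives 60 nM and compound 2 gives 40 nM, both within the scatter of compound 1, so the three are not separated. Compound 4 `COc1ccc(C(=C/C=C/C(=O)N[C@H](C)CCCc2cccnc2)c2ccc(OC)c(OC)c2)cc1OC` differs from compound 1 by methyl in place of hydrogen on a saturated chain carbon bound to an amide-type nitrogen and a saturated chain carbon. Within the data shown here, no measured pair isolates this change; compound 3, which also carries a branch on the chain carbon bound to the amide-type nitrogen, gives 60 nM and sits within the scatter of compound 1. A step no larger than the scatter, in either direction, is therefore expected, as a 1.1-fold lower number from compound 1 to compound 4 (0.04 log units; within the scatter). Compound 4 is estimated at 50 nM in this assay, with a range from 20 nM to 150 nM.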

Compound 4, half-maximal inhibitory concentration: 50 nM
For compound 4 middle estimate and measured number coincide at the digits printed, within the range that was stated.
By their numbers in this assay, from the lowest: compounds 2, 4, 1 and 3 (each within the scatter of the next).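

Methyl in place of hydrogen on a saturated chain carbon bound to an amide-type nitrogen and a saturated chain carbon gives a 1.1-fold lower number from compound 1 to compound 4 (0.04 log units; within the scatter) in this assay. Among these compounds, this is the first direct reading at this position, and it shows that this single branch on the 4-(pyridin-3-yl)butyl chain leaves the number within the scatter. No measured property bears on this result. The compounds shown leave open whether the mirror-image arrangement at this carbon, an ethyl group or a hydroxyl group in the same place would read alike.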